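This account rests on a few compounds, and the source may have more. Where it says the series, first, only, none or still open, it means among the compounds named here.

Compound 1 `Cc1ncsc1CCOC(=O)c1oc2cc(-c3ccccc3)cc(O)c2c1C` is the reference point. In a functional assay on WI-38 VA13 cells (Homo sapiens) for cytotoxicity (a higher number here means that more compound is needed for the effect, a lower number that less compound is needed), compound 1 gives 0.055 ug/mL, which is the higher of the two numbers available. Its nearest neighbour is compound 3 `COc1ccc(CCOC(=O)c2oc3cc(-c4ccccc4)cc(O)c3c2C)cc1OC`, which in this assay gives 0.021 ug/mL. The step of a 2.6-fold lower number from compound 1 to compound 3 (0.42 log units; beyond the scatter) changes only the tail of the ester and moves the number modestly downward. Compound 2 `Cc1c(C(=O)c2ccc(CN(C)C)cc2)oc2cc(-c3ccccc3)cc(O)c12` is a ketone instead of an ester. In this assay compound 2 gives only a limit, > 4 ug/mL. The unmeasured compound 4 `Cc1c(C(=O)c2ccc(F)c(F)c2)oc2cc(-c3ccccc3)cc(O)c12` differs from compound 1 by 3,4-difluorophenyl in place of 2-(4-methyl-1,3-thiazol-5-yl)ethoxy on a carbonyl carbon, so it too carries a ketone rather than an ester. Going by the values given here, the one measured step bears only on the tail of the ester, not on the ester-to-ketone change itself. The only ketone shown sits at the limit of > 4 ug/mL in this assay, at which 1 of the 3 values shown sits. On this basis compound 4 is expected to show a large rise in the number, the step of an 18-fold higher number from compound 1 to compound 4 (1.26 log units; beyond the scatter). For compound 4 the estimate in this assay is 1 ug/mL, within a range from 0.1 ug/mL to 4 ug/mL, with a real chance that only a limit is reported.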

Compound 4, half-maximal effective concentration: 0.4 ug/mL
For compound 4 the middle estimate is 2.5-fold (0.40 log units) above the measured one; the measured number falls inside the stated range.
By their numbers in this assay, from the lowest: compound 3; then compound 1; then compound 4. At a limit, above all of these: compound 2.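

In this assay, going by these compounds alone, placing 3,4-difluorophenyl in place of 2-(4-methyl-1,3-thiazol-5-yl)ethoxy on a carbonyl carbon gives a 7.3-fold higher number from compound 1 to compound 4 (0.86 log units; beyond the scatter), which is the first readable step from an ester to a ketone at this place. A ketone here can therefore still give a measured number, as compound 4 does with 0.4 ug/mL, although the number is higher than that of ester compound 1. Compound 2, the other ketone, gives only a limit, so the ketone alone does not settle the outcome, and the group it carries also counts: the limit of > 4 ug/mL in this assay, at which 1 of the 4 values shown sits.

Going by these compounds, how much of the step belongs to the ketone and how much to the 3,4-difluorophenyl ring remains open. How an amide on this carbonyl carbon, or a plain phenyl ketone, would read in this assay is also left open.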